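The source may report more compounds than this note shows. Statements on the series, on what has been measured and on what is new or still open speak of the compounds shown alone.

Working notes on the series. Among the compounds with values here, the three compounds measured so far share one core and differ only in the aryl group attached to it. In an in vitro functional assay on HEK285-7 cells for antagonist activity at prostaglandin D2 receptor 2 (Homo sapiens), read by BRET and beta-arrestin recruitment (on this read-out lower numbers stand for smaller maximal responses and higher numbers for larger maximal responses), compound 1 `O=C(O)Cc1sc(C(c2ccc(F)cc2)c2ccc(F)cc2)nc1-c1ccnc(N2CCCC2)c1` gives 80%. Compound 2 `O=C(O)Cc1sc(C(c2ccc(F)cc2)c2ccc(F)cc2)nc1-c1cccc(F)c1` gives 80% in this assay, and compound 3 `O=C(O)Cc1sc(C(c2ccc(F)cc2)c2ccc(F)cc2)nc1-c1cc(F)cc(F)c1` gives 80%. All three therefore stand level at the digits shown. Every step among them lies within the scatter: no change at the digits printed from compound 1 to compound 3 (within the scatter), no change at the digits printed from compound 2 to compound 3 (within the scatter), and likewise no change at the digits printed from compound 1 to compound 2 (within the scatter). Nothing in the measured set moves the maximal response beyond the scatter.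

Compound 4 `O=C(O)Cc1sc(C(c2ccc(F)cc2)c2ccc(F)cc2)nc1-c1ccnc(N2CCC2)c1` has not yet been measured in this assay. The change from compound 3 is 2-(azetidin-1-yl)pyridin-4-yl in place of 3,5-difluorophenyl on an aromatic carbon. Within the data shown here, the step that bears most on it is the one from compound 1 to compound 3, in which 2-(pyrrolidin-1-yl)pyridin-4-yl gave way to 3,5-difluorophenyl with no change at the digits printed from compound 1 to compound 3 (within the scatter); compound 4 runs that exchange in the opposite sense, with an azetidine ring entering where compound 1 carried a pyrrolidine ring. The other two steps, no change at the digits printed from compound 1 to compound 2 (within the scatter) and no change at the digits printed from compound 2 to compound 3 (within the scatter), point the same way. No step beyond the scatter is therefore expected: no change at the digits printed from compound 3 to compound 4 (within the scatter). Compound 4 is estimated to give 80% in this assay, with an expected range from 70% to 90%.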

Compound 4, largest response reached (reported as efficacy), in percent of the reference or control that the assay uses: 80%
For compound 4 middle estimate and measured number coincide at the digits printed; low and high end bracket the measured number.
By their numbers in this assay, from the lowest: compounds 1, 2, 3 and 4 (each within the scatter of the next).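

Within the 2-substituted pyridin-4-yl group, azetidin-1-yl in place of pyrrolidin-1-yl gives no change at the digits printed from compound 1 to compound 4 (within the scatter) in this assay and is the first change in the series confined to the saturated ring, since the earlier steps exchanged the whole aryl group or added fluoro. The aryl position also tolerates this new group without a step beyond the scatter, with no change at the digits printed from compound 3 to compound 4 (within the scatter) and no change at the digits printed from compound 2 to compound 4 (within the scatter) as the readings, even though 2-(azetidin-1-yl)pyridin-4-yl counts 2 hydrogen-bond acceptors and two ring atoms against none of either in 3,5-difluorophenyl and 3-fluorophenyl. No supporting data bear on why the maximal response stays level across these exchanges.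

All four compounds remain level, so the shown set gives no group at this position that moves the maximal response beyond the scatter, and it cannot rank the groups or show which features of the aryl group matter. It remains open whether piperidin-1-yl, morpholin-4-yl or an open-chain dimethylamino group in place of azetidin-1-yl would also stay level, or whether a primary amine there would separate from the compounds shown.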